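The compounds below may be only part of what the source reports. "The series", "measured", "known", "first", "only" and "open" are said of these compounds alone.

Measured so far in an assay on CHO cells for inhibition of sodium- and chloride-dependent glycine transporter 1 (Homo sapiens), read by scintillation counting; a higher number here means that more compound is needed for the effect, a lower number that less compound is needed:
Compound 1 `C[C@H](Oc1ccc(S(C)(=O)=O)cc1C(=O)N1Cc2ccccc2C1)C(F)(F)F`: 2540 nM
Compound 2 `C[C@H](Oc1ccc(S(C)(=O)=O)cc1C(=O)N1Cc2ccc(-c3ccncc3)cc2C1)C(F)(F)F`: 17 nM
Compound 3 `CC(C)Oc1ccc(S(C)(=O)=O)cc1C(=O)N1Cc2cc(C(F)(F)F)cnc2C1`: 70 nM

Compound 3 holds the middle of the three numbers in this assay: its value lies well under that of compound 1 and somewhat above that of compound 2. Going by the values given here, compound 3 differs from compound 1 and from compound 2 in more than one place, so only the values themselves can be set side by side; no single step is defined there.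

Compound 4 `CS(=O)(=O)c1ccc(OCCC(F)(F)F)c(C(=O)N2Cc3cc(C(F)(F)F)cnc3C2)c1` is the next compound, not yet measured. Against compound 3 it changes only the ether side chain: 3,3,3-trifluoropropyl in place of isopropyl on an oxygen on an aromatic ring. Among the compounds with values here, no measured step touches this position. Within the data shown here, the only single-place step in the set, a 150-fold lower number from compound 1 to compound 2 (2.17 log units; beyond the scatter), concerns a different part of the shared core and does not bear on the ether. With nothing to go on beyond the unchanged remainder of the structure, a step in this assay no larger than the usual scatter is expected, direction open: a 1.1-fold higher number from compound 3 to compound 4 (0.06 log units; within the scatter). Compound 4 is therefore estimated at 80 nM, with a range from 30 nM to 250 nM.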

Compound 4, half-maximal effective concentration: 111 nM
For compound 4 the middle estimate is 1.4-fold (0.14 log units) below the measured one; the range from low to high includes it.
By their numbers in this assay, from the lowest: compound 2; then compounds 3 and 4 (each within the scatter of the next); then compound 1.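

In this assay the ether side chain now has its first single-place reading: 3,3,3-trifluoropropyl in place of isopropyl gives a 1.6-fold higher number from compound 3 to compound 4 (0.20 log units; within the scatter) and stays within the scatter. On the core of compound 3, this position therefore accepts a side chain of 6 heavy atoms, fluorine among them, in place of one of 3 heavy atoms with no clear shift in the number. No measurement at hand offers an explanation for this result.

Going by these compounds, only these two side chains can be compared at this position, so it remains open whether an amine, a carboxylic acid or a longer chain on the oxygen would also leave the number within the scatter. Also open, on these data alone, is whether the same change reads alike on the core of compound 2, which carries pyridin-4-yl.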